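This account rests on a few compounds, and the source may have more. Where it says the series, first, only, none or still open, it means among the compounds named here.

Compounds measured in a functional assay on HEK293 cells for agonist activity at Vasopressin V2 receptor (Homo sapiens), read by a luciferase reporter and cAMP accumulation; on this read-out lower numbers stand for an effect already at smaller amounts and higher numbers for an effect only at larger amounts of compound:
Compound 1 `Cc1cc(C(=O)N2CCCCc3ccccc32)ccc1CNC(=O)Nc1c(F)cccc1F`: 2.1 nM
Compound 2 `CCOC(=O)CNC(=O)NCc1ccc(C(=O)N2CCCCc3ccccc32)cc1C`: 140 nM
Compound 3 `CO[C@@H]1C[C@@H](C(=O)N(C)C)N(C(=O)NCc2ccc(C(=O)N3CCCCc4ccccc43)cc2C)C1`: 4.7 nM

Compound 3 stands second highest of the three numbers in this assay. Its nearest neighbour is compound 1, separated by a 2.2-fold higher number from compound 1 to compound 3 (0.35 log units; beyond the scatter); its furthest is compound 2, separated by a 30-fold lower number from compound 2 to compound 3 (1.47 log units; beyond the scatter). Compound 4 `Cc1cc(C(=O)N2CCCCc3ccccc32)ccc1CNC(=O)N1C[C@H](OC(C)(C)C)C[C@H]1C(=O)N(C)C` is not yet measured. It differs from compound 3 in one place only: tert-butyl in place of methyl on an oxygen on a saturated carbon; read one bond further out, methoxy becomes tert-butoxy. Within the data shown here, none of the measured steps touches this oxygen: both a 67-fold higher number from compound 1 to compound 2 (1.82 log units; beyond the scatter) and a 2.2-fold higher number from compound 1 to compound 3 (0.35 log units; beyond the scatter) concern the group on the urea carbonyl, and they were large and modest. The data therefore give no direct guide for the change in compound 4, and a step of at most modest size is expected, a 1.3-fold higher number from compound 3 to compound 4 (0.11 log units; within the scatter), with the number staying close to that of compound 3. Compound 4 is estimated at 6 nM in this assay, in the range 2 nM to 20 nM.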

Compound 4, half-maximal effective concentration: 46 nM
The estimate for compound 4 lay 7.7-fold (0.88 log units) below the measured number, and the stated range ends below it.
By their numbers in this assay, from the lowest: compound 1; then compound 3; then compound 4; then compound 2.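

In this assay, tert-butyl in place of methyl on this oxygen gives a 9.8-fold higher number from compound 3 to compound 4 (0.99 log units; beyond the scatter), so the position is not indifferent to what it carries. The earlier steps shown here changed only the group on the urea carbonyl; this one shows that a change further out on the pyrrolidine, from 1 carbon to 4 carbons on the oxygen, also moves the number beyond the scatter. No supporting measurement is available to explain this shift.

With only methoxy and tert-butoxy at this place, the compounds shown leave open how intermediate groups such as ethoxy or isopropoxy would read, and so whether the number climbs gradually with the size of the chain. They also leave open what a free hydroxyl or an amine at this place would give.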